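This account rests on a few compounds, and the source may have more. Where it says the series, first, only, none or still open, it means among the compounds named here.

Measured so far in a functional assay on NCI-H522 cells (Homo sapiens) for cytotoxicity, read by sulforhodamine B assay, with a stated time of 48 h, tested at 100 uM; a lower number here means a stronger effect, a higher number a weaker effect of the compound at the concentration tested:
compound 1, `COc1cc(-c2cc(/C=C/C(=O)c3ccc(Cl)c(Cl)c3)[nH]n2)cc(OC)c1OC`, gives -65%
compound 2, `COc1ccc(C(=O)/C=C/c2cc(-c3cc(OC)c(OC)c(OC)c3)n[nH]2)cc1OC`, gives -97%

Going by the values given here, compound 2 thus stands lowest of the two numbers; the only step known is a number 32 percentage points lower from compound 1 to compound 2 (beyond the scatter). Compound 3, `COc1ccc(C(=O)/C=C/c2cc(-c3cc(OC)c(OC)c(OC)c3)n[nH]2)cc1`, differs from compound 2 by hydrogen in place of methoxy on an aromatic carbon. Among the compounds with values here, no measured step removes a single methoxy, so the one known step gives only loose guidance; a modest weakening or none beyond the scatter is expected, as a number 12 percentage points higher from compound 2 to compound 3 (beyond the scatter). For compound 3 in this assay the expected value is -85%, within -100% to -50%.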

Compound 3, a percentage reported as activity, at one concentration (the size of the read-out at that concentration, not a potency): -62%
For compound 3 the middle estimate is 23 percentage points below the measured one, within the range that was stated.
By their numbers in this assay, from the lowest: compound 2; then compounds 1 and 3 (each within the scatter of the next).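

In this assay, going from 3,4-dimethoxyphenyl to 4-methoxyphenyl gives up much of the effect, with a number 35 percentage points higher from compound 2 to compound 3 (beyond the scatter), so the removed methoxy matters in this series. Replacing 3,4-dichlorophenyl with 4-methoxyphenyl brings no clear change, with a number 3 percentage points higher from compound 1 to compound 3 (within the scatter), so among these three compounds only the 3,4-dimethoxyphenyl compound stands apart. No measurement at hand explains this loss.

On these data alone, whether a hydroxy group, an amine or a longer ethoxy chain in place of the removed methoxy would keep the effect of compound 2 remains open.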